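Compound 4: 2-methoxyphenyl in place of naphthalen-2-yl

The source may report more compounds than this note shows. Statements on the series, on what has been measured and on what is new or still open speak of the compounds shown alone.

Compound 1 `O=C(COc1ccc2ccccc2c1)N1CCN(C(c2ccc(Br)cc2)c2ccc(Br)cc2)CC1` is one of three compounds tested in a functional assay on PC-12 cells (Rattus norvegicus) for cytotoxicity, read by MTT assay, with a stated time of 24 h, tested at 1 uM; on this read-out lower numbers stand for a weaker effect and higher numbers for a stronger effect at the one concentration tested. In this assay compound 1 gives 7.87%. Compound 2 `Cc1ccc(C(c2ccc(C)cc2)N2CCN(C(=O)COc3ccc4ccccc4c3)CC2)cc1` gives 5.63%, and compound 3 `COc1ccc(OCC(=O)N2CCN(C(c3ccc(F)cc3)c3ccc(F)cc3)CC2)cc1` gives 5.26%. Compound 1 has the highest of the three numbers, but its gaps to compound 2 and to compound 3 both lie within the usual scatter, so the three read as alike. Compound 4 `COc1ccccc1OCC(=O)N1CCN(C(c2ccc(Br)cc2)c2ccc(Br)cc2)CC1` has not been measured. It differs from compound 1 in one place: 2-methoxyphenyl in place of naphthalen-2-yl on an oxygen on a saturated carbon. For the measured compounds named here, no two measured compounds differ in only one place, so no measured step guides the expectation. Since all three measured numbers are low and close, the step of a number 0.9 percentage points lower from compound 1 to compound 4 (within the scatter) is expected to be none beyond the scatter. Compound 4 is expected to give about 7%, within a range from 2% to 14%.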

Compound 4, a percentage reported as activity, at one concentration (the size of the read-out at that concentration, not a potency): 12.8%
Compound 4: middle estimate off by 5.8 percentage points, on the low side, within the range that was stated.
By their numbers in this assay, from the lowest: compounds 3, 2, 1 and 4 (each within the scatter of the next).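

In this assay, for the compounds shown here, putting 2-methoxyphenyl in place of naphthalen-2-yl on an oxygen on a saturated carbon gives a number 4.9 percentage points higher from compound 1 to compound 4 (within the scatter) and is the only one-place comparison so far. At this position, then, two six-membered aromatic rings can give way to one ring carrying a methoxy group with no change beyond the scatter. No evidence at hand offers an explanation for this step. Going by these compounds, whether a carboxylic acid or an amine at this position would read differently stays open, as does the same swap on the cores of compound 2 and compound 3.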